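The source may hold more compounds than are shown below. What is called first, only, known or untested is meant among the compounds shown, and "the series" means these compounds.

Compound 1 `Cc1ccc(-c2noc(CCCCCCC(=O)NO)n2)cc1` — 5390 nM
Compound 2 `O=C(CCCCCCc1nc(-c2ccccc2Cl)no1)NO` — 3650 nM

Both compounds were tested in an assay on isolated protein for inhibition of histone deacetylase 8 (Homo sapiens), read by fluorescence, with a stated time of 10 min; a lower number here means a stronger inhibitor, a higher number a weaker inhibitor. Going by the values given here, of the two numbers, the one for compound 2 is the smaller, but the step of a 1.5-fold lower number from compound 1 to compound 2 (0.17 log units; within the scatter) lies within the scatter, so the two compounds cannot be told apart on this evidence. That step replaced one aromatic group with another on the same carbon of the shared core, and it moved the number very little.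

Compound 3 `O=C(CCCCCCc1nc(-c2cccs2)no1)NO` has not yet been measured. It differs from compound 2 in the same position: thiophen-2-yl in place of 2-chlorophenyl on an aromatic carbon. Among the compounds with values here, the only measured step that bears on this change is the one from compound 1 to compound 2, where a different exchange of the aromatic group on that carbon stayed within the scatter. On that basis, the exchange for a thiophen-2-yl is expected to give no step beyond the scatter in this assay, in either direction. Compound 3 is therefore expected to give about 3500 nM, with a likely range from 1500 nM to 8000 nM. That amounts to an expected step of a 1.0-fold lower number from compound 2 to compound 3 (0.02 log units; within the scatter), which is no change beyond the scatter.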

Compound 3, half-maximal inhibitory concentration: 1920 nM
Estimate against measurement, compound 3: 1.8-fold (0.26 log units) above, and the stated range covers the measured number.
By their numbers in this assay, from the lowest: compounds 3, 2 and 1 (each within the scatter of the next, the first and the last beyond it).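

This position tolerates a five-membered aromatic ring with one hetero atom in place of a six-membered ring of carbon only: in this assay, putting thiophen-2-yl where 2-chlorophenyl stood gives a 1.9-fold lower number from compound 2 to compound 3 (0.28 log units; within the scatter), so this pair still cannot be told apart. Going by these compounds alone, the new information lies in the other comparison, where thiophen-2-yl in place of 4-methylphenyl gives a 2.8-fold lower number from compound 1 to compound 3 (0.45 log units; beyond the scatter), the first step at this position that clears the scatter and a sign that the group on this carbon can shift the number, if only modestly. Nothing measured here says why the number shifts with this exchange of groups.

The compounds shown carry only aromatic rings on this carbon, so how an amine or a carboxylic acid at the same place would read in this assay stays open. Also open, on these data alone, is whether an unsubstituted phenyl or a furan-2-yl, with oxygen as the ring hetero atom instead of sulfur, would read closer to compound 3 or to compound 1.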